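Methoxy Scan on a Pyrazoline Thiazolone Series

The compounds below may be only part of what the source reports. "The series", "measured", "known", "first", "only" and "open" are said of these compounds alone.

Measured so far:
compound 1, `COc1ccc(C2=NN(C3=NC(=O)/C(=C4\C(=O)Nc5ccccc54)S3)C(c3ccc(OC)cc3)C2)cc1`, 100000 nM
compound 2, `O=C1N=C(N2N=C(c3ccccc3)CC2c2ccc(Cl)cc2)S/C1=C1/C(=O)Nc2ccccc21`, 280 nM

In a functional assay on cells (Melanoma cell, Homo sapiens) for cytotoxicity, read by sulforhodamine B assay, with a stated time of 48 h (a lower number here means a stronger inhibitor of growth, a higher number a weaker inhibitor of growth), compound 2 gives 280 nM, the lowest number of the two. Compound 1 gives a far higher number in this assay, and the gap between them lies well beyond the scatter; the two structures differ at more than one place, so the values only show that compound 1 is the weaker growth inhibitor.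

Compound 3, `COc1ccc(C2=NN(C3=NC(=O)/C(=C4\C(=O)Nc5ccccc54)S3)C(c3ccc(Cl)cc3)C2)cc1`, is compound 2 with one change: methoxy in place of hydrogen on an aromatic carbon. Among the measured compounds shown here, no step between measured compounds isolates this change. Since compound 1, which carries methoxy groups on both aryl rings, gives 100000 nM, the expectation is a step toward a higher number, of uncertain size. Compound 3 is estimated at 3000 nM, range 400 nM to 40000 nM, an expected step of an 11-fold higher number from compound 2 to compound 3 (1.03 log units; beyond the scatter).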

Compound 3, concentration for 50% growth inhibition: 100000 nM
For compound 3 the middle estimate is 33-fold (1.52 log units) below the measured one; the whole stated range lies below it.
By their numbers in this assay, from the lowest: compound 2; then compounds 1 and 3 (each within the scatter of the next).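

In this assay, the change from phenyl to 4-methoxyphenyl is by itself a large step: a 360-fold higher number from compound 2 to compound 3 (2.55 log units; beyond the scatter). Among the compounds shown here, this is the first single-change reading at this position, and it shows that this one methoxy is enough to separate compound 3 from compound 2. With that methoxy present, chloro in place of methoxy on the other aryl ring gives no change at the digits printed from compound 1 to compound 3 (within the scatter), so that exchange shows no response against this background, whereas the methoxy step is large; no evidence on the cause of either result is available.

The compounds shown leave open whether a fluoro, a methyl or a hydroxy at this position would give a step like that of methoxy. Also open, as far as these compounds go, is whether the exchange of chloro for methoxy on the other aryl ring would still show no response with an unsubstituted phenyl at this position.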